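This account rests on a few compounds, and the source may have more. Where it says the series, first, only, none or still open, it means among the compounds named here.

Measured in a toxicity assay on J774.A1 cells (Mus musculus) for cytotoxicity, read by SYBR Green assay, with a stated time of 1 h; on this read-out higher numbers stand for an effect only at larger amounts of compound and lower numbers for an effect already at smaller amounts:
Compound 1 `CN(C)c1ccc2cc(-c3ccccc3Br)c(N)nc2c1`: 12000 nM
Compound 2 `Cc1ccccc1-c1cc2ccc(N(C)C)cc2nc1N`: 6800 nM
Compound 3 `CN(C)c1ccc2cc(-c3ccc(Cl)cc3)c(N)nc2c1`: 2900 nM

Of these three, compound 3 gives the lowest number, 2900 nM. Compound 4 `CN(C)c1ccc2cc(-c3ccccn3)c(N)nc2c1` has not yet been measured. It carries pyridin-2-yl in place of 4-chlorophenyl on an aromatic carbon.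

Going by the values given here, two measured steps bear on this change, since both bring in the 4-chlorophenyl group: a 4.1-fold lower number from compound 1 to compound 3 (0.62 log units; beyond the scatter) and a 2.3-fold lower number from compound 2 to compound 3 (0.37 log units; beyond the scatter). Among the compounds with values here, no measured compound has a ring with a hetero atom at this place, so the evidence is indirect. Losing the 4-chlorophenyl group is therefore expected to give a modest rise in this assay.

The expected change is a 2.1-fold higher number from compound 3 to compound 4 (0.32 log units; beyond the scatter). For compound 4 the estimated value is 6000 nM, within an expected range of 2500 nM to 15000 nM.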

Compound 4, half-maximal effective concentration: 2200 nM
Compound 4: middle estimate off by 2.7-fold (0.44 log units), on the high side; the whole stated range lies above it.
By their numbers in this assay, from the lowest: compounds 4 and 3 (each within the scatter of the next); then compounds 2 and 1 (each within the scatter of the next).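

In this assay, a ring with a hetero atom at this place holds the low end of the series: pyridin-2-yl in place of 4-chlorophenyl leaves the number within the scatter (a 1.3-fold lower number from compound 3 to compound 4 (0.12 log units; within the scatter)), so the chlorine-bearing ring is not required for it. Against the two ring groups of the other compounds, pyridin-2-yl also reads lower (a 3.1-fold lower number from compound 2 to compound 4 (0.49 log units; beyond the scatter); a 5.5-fold lower number from compound 1 to compound 4 (0.74 log units; beyond the scatter)). Nothing measured here accounts for this result. On these data alone, whether pyridin-3-yl, pyridin-4-yl, or a phenyl ring carrying an amine or a carboxylic acid would read alike at this place remains open.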